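A few compounds are considered here, and "the series" means these few. Any claim that something is new, unique, unknown or untested is made for them only; others in the source may bear on it.

Measured in an ADME assay on Huh-7 cells (Homo sapiens) for cytotoxicity, with a stated time of 72 h; a lower number here means that less compound is tolerated, a higher number that more compound is tolerated:
Compound 1 `CC(C)CCn1nc(C2=CCCC2)c(O)c(C2=NS(=O)(=O)c3cc(NS(C)(=O)=O)ccc3N2)c1=O`: > 1000 nM.
Compound 2 `CS(=O)(=O)Nc1ccc2c(c1)S(=O)(=O)N=C(c1c(O)c(-c3cccs3)nn(CC3CCC3)c1=O)N2`: > 1000 nM.

For compound 1 the reading > 1000 nM is a limit of the assay, not a number. For compound 2 the reading > 1000 nM is likewise a limit, not a number. Compound 2 thus stands where every value shown stands, namely at the limit of > 1000 nM in this assay, at which 2 of the 2 values shown sit. For the measured compounds named here, no two measured compounds differ in a single place, so no step has been measured in this assay.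

Compound 3 `CS(=O)(=O)Nc1ccc2c(c1)S(=O)(=O)N=C(c1c(O)c(-c3cccs3)nn(CC3(C(F)(F)F)CC3)c1=O)N2` has not yet been measured in this assay. It differs from compound 2 as follows: 1-(trifluoromethyl)cyclopropyl in place of cyclobutyl on a saturated chain carbon bound to an aromatic nitrogen. Since both measured values sit at the limit, the expected step in this assay is a step that the limit leaves unreadable from compound 2 to compound 3, nothing beyond the usual scatter. Compound 3 is expected to give 1500 nM in this assay, within a range of 700 nM to 5000 nM, and most likely to be reported again only as a limit.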

Compound 3, half-maximal cytotoxic concentration: > 1000 nM
Compound 3: a limit, no number; the forecaster's own chance of this, stated with the estimate: 80%; the middle value lies beyond the limit too.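

The step from compound 2 to compound 3 cannot be read in this assay, as both readings are limits and not numbers: the limit of > 1000 nM in this assay, at which 3 of the 3 values shown sit.

The compounds shown leave open at what concentration any of them becomes cytotoxic, and whether 1-(trifluoromethyl)cyclopropyl in place of cyclobutyl changes that concentration.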